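Replacing the Side Chain of Compound 3

The source may hold more compounds than are shown below. What is called first, only, known or untested is meant among the compounds shown, and "the series" means these compounds.

In an ADME assay for permeability, using PAMPA, with a stated time of 4 h, at pH 7.4 (on this read-out higher numbers stand for higher permeability and lower numbers for lower permeability), compound 1 `CN(C[C@H]1Cc2ncccc2CN1)[C@H]1CCCc2cccnc21` gives 1300 nm/s and stands highest of the three measured compounds. Compound 2 `c1cnc2c(c1)CN[C@@H](CN(CCCCNC1CCOCC1)[C@H]1CCCc3cccnc31)C2` gives 8 nm/s and compound 3 `CN(CCCCN(C[C@H]1Cc2ncccc2CN1)[C@H]1CCCc2cccnc21)C1CCOCC1` gives 490 nm/s as the second highest number. Compound 3 thus sits in the middle, with a 2.7-fold lower number from compound 1 to compound 3 (0.42 log units; beyond the scatter) on one side and a 61-fold higher number from compound 2 to compound 3 (1.79 log units; beyond the scatter) on the other.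

Among the measured compounds shown here, compound 4 `c1cnc2c(c1)CN[C@@H](CN(CCCC1CCNCC1)[C@H]1CCCc3cccnc31)C2` alters the chain of compound 3 through piperidin-4-yl in place of (methyl(oxan-4-yl)amino)methyl on a saturated chain carbon, three bonds along the chain from an amine nitrogen as its single change, piperidin-4-yl in place of (methyl(oxan-4-yl)amino)methyl on a saturated chain carbon, three bonds along the chain from an amine nitrogen.

For the measured compounds named here, two measured steps bear on this change. Adding a chain that keeps a hydrogen on its amine nitrogen gave a 160-fold lower number from compound 1 to compound 2 (2.21 log units; beyond the scatter) as a large step, and methyl in place of that hydrogen gave a 61-fold higher number from compound 2 to compound 3 (1.79 log units; beyond the scatter) as another. Compound 4, like compound 2, has a hydrogen on an amine nitrogen of the chain. Going by the values given here, no measured compound carries piperidin-4-yl, so the comparison is only partial. A large downward step is therefore expected in this assay, possibly somewhat short of the full gap between compound 2 and compound 3.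

The expected step is a 20-fold lower number from compound 3 to compound 4 (1.29 log units; beyond the scatter) by this estimate. For compound 4 the estimated value is 25 nm/s with an expected range from 6 nm/s to 120 nm/s in this read-out.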

Compound 4, apparent permeability: 24 nm/s
Compound 4: middle estimate off by 1.0-fold (0.02 log units), on the high side; the measured number falls inside the stated range.
By their numbers in this assay, from the lowest: compound 2; then compound 4; then compound 3; then compound 1.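

In this assay, piperidin-4-yl in place of (methyl(oxan-4-yl)amino)methyl gives a 20-fold lower number from compound 3 to compound 4 (1.31 log units; beyond the scatter), which shows that a large fall at this place on the chain is not confined to the removal of methyl from compound 3. The new group, which counts one hydrogen-bond donor where the group it replaces counts none, does not land level with the ((oxan-4-yl)amino)methyl chain end, giving a 3.0-fold higher number from compound 2 to compound 4 (0.48 log units; beyond the scatter), so the two chains that keep a hydrogen on a chain nitrogen still differ, though by far less than either differs from compound 3. Against the compound without the extra chain, 2-(piperidin-4-yl)ethyl gives a 54-fold lower number from compound 1 to compound 4 (1.73 log units; beyond the scatter), and among the four compounds no measurement explains these differences.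

On these data alone, what stays open is whether methyl on the nitrogen of the piperidin-4-yl ring would raise the number as methyl on the chain amine did in a 61-fold higher number from compound 2 to compound 3 (1.79 log units; beyond the scatter). As far as these compounds go, it is also open whether an amide at that chain nitrogen, or a shorter chain carrying the same piperidin-4-yl group, would sit nearer compound 3 or compound 4.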